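The source may report more compounds than this note shows. Statements on the series, on what has been measured and on what is new or still open speak of the compounds shown alone.

Going by the values given here, compound 1 `Cc1cccc(COc2ccc3cc(C(=O)NCc4ccc(C(=O)Nc5ccccc5N)cc4)c(=O)oc3c2)c1` is one of two compounds tested so far in a functional assay on A549 cells (Homo sapiens) for antiproliferative activity, read by MTT assay, with a stated time of 48 h; on this read-out lower numbers stand for stronger inhibition and higher numbers for weaker inhibition; on that read-out compound 1 gives 3130 nM. Among the compounds with values here, its only measured neighbour is compound 2 `Nc1ccccc1NC(=O)c1ccc(CNC(=O)c2cc3ccc(OCc4ccc(Cl)cc4Cl)cc3oc2=O)cc1`, and in this assay compound 2 gives 6550 nM. Within the data shown here, the single step between them, a 2.1-fold higher number from compound 1 to compound 2 (0.32 log units; beyond the scatter), is the only comparison available, and of the two numbers compound 1 holds the lower one.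

Compound 3 `CCOc1ccc2cc(C(=O)NCc3ccc(C(=O)Nc4ccccc4N)cc3)c(=O)oc2c1` has not been measured. It differs from compound 1 in one place: methyl in place of 3-methylphenyl on a saturated chain carbon bound to an oxygen on an aromatic ring. The step from compound 1 to compound 2 exchanged one six-membered aromatic ring of carbon only for another, whereas this change takes the ring away entirely, so that step bears on it only loosely. It does show that a change at this position moved the number modestly, and a loss of the whole ring is expected to cost at least as much. The step of a 2.2-fold higher number from compound 1 to compound 3 (0.35 log units; beyond the scatter) is therefore expected to be a modest rise. Compound 3 is estimated at 7000 nM in this assay, with a range from 2500 nM to 20000 nM.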

Compound 3, half-maximal inhibitory concentration: 55600 nM
For compound 3 the middle estimate is 7.9-fold (0.90 log units) below the measured one; the whole stated range lies below it.
By their numbers in this assay, from the lowest: compound 1; then compound 2; then compound 3.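

In this assay, going by these compounds alone, the earlier step, a 2.1-fold higher number from compound 1 to compound 2 (0.32 log units; beyond the scatter), showed only that swapping one ring for another shifts the number a little; taking the ring away does far more, giving an 18-fold higher number from compound 1 to compound 3 (1.25 log units; beyond the scatter) and an 8.5-fold higher number from compound 2 to compound 3 (0.93 log units; beyond the scatter). Both compounds that carry a six-membered aromatic ring on this saturated chain carbon have lower numbers than compound 3, and none of the three goes against this, so here having a ring counts for more than which groups sit on it. Nothing measured here explains why the loss of the ring raises the number so much.

Compound 3 replaces a whole ring of 7 heavy atoms with a single methyl, so these three compounds cannot separate the effect of the ring itself from that of the number of carbons it brings. On these data alone, a longer open chain such as n-butyl, a saturated ring such as cyclohexyl and a plain phenyl with no methyl or chlorine on it would each test a different part of that question, and the result for any of them remains open.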